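A few compounds are considered here, and "the series" means these few. Any claim that something is new, unique, unknown or untested is made for them only; others in the source may bear on it.

Compounds measured so far in a functional assay on PC-3 cells (Homo sapiens) for antiproliferative activity, read by MTT assay, with a stated time of 72 h; a higher number here means a weaker inhibitor, a lower number a stronger inhibitor:

compound 1 `O=C(N/N=C/c1ccc(Br)cc1)Nc1ccc(Oc2ccnc3[nH]ccc23)c(F)c1` gives 920 nM
compound 2 `O=C(N/N=C/c1ccc(O)cc1)Nc1ccc(Oc2ccnc3[nH]ccc23)c(F)c1` gives 2780 nM
compound 3 `O=C(N/N=C/c1ccc(Br)cc1)Nc1ccc(Oc2ccnc3[nH]ccc23)cc1` is reported as "not active" (no number reported) with no number

Compound 3 therefore has no single number in this assay and offers no fixed point from which to count a step. The next compound, compound 4 `O=C(N/N=C/c1ccc(O)cc1)Nc1ccc(Oc2ccnc3[nH]ccc23)cc1`, differs from it in one place, with hydroxy in place of bromo on an aromatic carbon, para to a large group hydroxy in place of bromo on an aromatic carbon and so turns 4-bromophenyl into 4-hydroxyphenyl.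

Among the compounds with values here, one measured step bears on this change. The same exchange, made on a different core, gave a 3.0-fold higher number from compound 1 to compound 2 (0.48 log units; beyond the scatter) and that modest step lies beyond the scatter. A modest step toward a higher number, meaning a weaker inhibitor, is thus the expected direction and size, though it cannot be counted from compound 3 in the absence of a number. The expectation rests on compound 2 at 2780 nM as the nearest measured hydroxy compound and on compound 3 with its reading of "not active" (no number reported) as a sign that the number may lie higher still. Compound 4 is estimated at 8000 nM with an expected range from 2500 nM to 30000 nM in this assay as the likely span. It is also quite possible, on this expectation, that no number is reported at all.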

Compound 4, half-maximal inhibitory concentration: 4920 nM
The estimate for compound 4 lay 1.6-fold (0.21 log units) above the measured number; the measured number falls inside the stated range.
By their numbers in this assay, from the lowest: compound 1; then compounds 2 and 4 (each within the scatter of the next).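

In this assay, the exchange of bromo for hydroxy now has a second reading: on the core without fluoro, the 4-hydroxyphenyl compound 4 carries a number while the 4-bromophenyl compound 3 has none, so the step between them cannot be read, and the ranking of a 3.0-fold higher number from compound 1 to compound 2 (0.48 log units; beyond the scatter), where bromo gave the lower number, is not seen again here. Among the hydroxy compounds, removing fluoro gives a 1.8-fold higher number from compound 2 to compound 4 (0.25 log units; within the scatter), which lies within the scatter, whereas among the bromo compounds, compound 1 gives 920 nM and compound 3 has no number, so the fluoro exchange reads differently with the two groups. Nothing shown here offers an explanation for this difference.

The compounds shown leave open whether the bromo compound without fluoro has any measurable activity at a higher concentration, so the true size of that gap remains unknown. They also leave open how an amine or a methoxy group would read on the aromatic carbon para to a large group, and whether chloro would behave as fluoro does.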